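The compounds below may be only part of what the source reports. "The series", "measured", "known", "first", "only" and "open" are said of these compounds alone.

Compound 1 `CC(C)(C)c1ccc(NC(=O)c2ccc(-c3ncccc3F)cc2)cc1` gives 3 nM in a functional assay for antagonist activity at transient receptor potential cation channel subfamily V member 1 (Homo sapiens), read by FLIPR; a lower number here means a stronger inhibitor, a higher number a weaker inhibitor.
Compound 2 `CC(C)(C)c1ccc(NC(=O)c2ccc(-c3ncccc3-c3ncc[nH]3)cc2)cc1` gives 3670 nM in this assay.
Compound 3 `CC(C)(C)c1ccc(NC(=O)c2ccc(-c3ncccc3-c3nnco3)cc2)cc1` gives 91 nM in this assay.

Among these three numbers compound 3 stands second highest. The step of a 30-fold higher number from compound 1 to compound 3 (1.48 log units; beyond the scatter) separates it from compound 1, and the step of a 40-fold lower number from compound 2 to compound 3 (1.61 log units; beyond the scatter) separates it from compound 2; both gaps are beyond the usual scatter.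

Compound 4 `CC(C)(C)c1ccc(NC(=O)c2ccc(-c3ncccc3-c3nn[nH]n3)cc2)cc1` has not yet been measured. It differs from compound 3 in one place: 2H-tetrazol-5-yl in place of 1,3,4-oxadiazol-2-yl on an aromatic carbon. Within the data shown here, two measured steps bear on this change, since each of them also puts a five-membered aromatic ring in place of fluoro on the same aromatic carbon: the step of a 30-fold higher number from compound 1 to compound 3 (1.48 log units; beyond the scatter) and the much larger step a 1200-fold higher number from compound 1 to compound 2 (3.09 log units; beyond the scatter). The ring entering in compound 4 carries one hydrogen-bond donor, as the ring in compound 2 does, whereas the ring in compound 3 carries none. The step from compound 3 to compound 4 is therefore expected to raise the number, an 8.8-fold higher number from compound 3 to compound 4 (0.94 log units; beyond the scatter), with wide uncertainty. Compound 4 is estimated at 800 nM, within a range from 150 nM to 5000 nM.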

Compound 4, half-maximal inhibitory concentration: > 4000 nM
Compound 4 was reported as a limit; the forecaster's own chance of this, stated with the estimate: 10%; middle value at least 5.0-fold (0.69 log units) from the limit.
By their numbers in this assay, from the lowest: compound 1; then compound 3; then compound 2. At a limit, above all of these: compound 4.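

Compound 4 is reported only as a limit of the assay, not as a number: the limit of > 4000 nM in this assay, at which 1 of the 4 values shown sits. Putting 2H-tetrazol-5-yl in place of 1,3,4-oxadiazol-2-yl, a ring with the same number of heavy atoms, gives an at least 43-fold higher number from compound 3 to compound 4 (1.64 log units; beyond the scatter), and the comparison with fluoro gives an at least 1300-fold higher number from compound 1 to compound 4 (3.12 log units; beyond the scatter), so at this position two five-membered rings of equal size can differ widely. Compound 2 and compound 4, whose rings each carry a hydrogen-bond donor, both lie well above compound 3, whose ring carries none, while an at least 1.0-fold higher number from compound 2 to compound 4 (0.03 log units; that floor lies within the scatter) leaves those two unordered.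

As far as these compounds go, the true number for compound 4 remains unknown, and the donor cannot be separated from the other atom changes in these rings. A methyl group on the tetrazole in place of its hydrogen, or a small methoxy group in place of the ring, would be needed to test this.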